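Swapping a dimethyloxetane for an oxolane ring

This account rests on a few compounds, and the source may have more. Where it says the series, first, only, none or still open, it means among the compounds named here.

Of the compounds shown here, three sharing one core have been measured in an ADME assay on microsomes from liver (Homo sapiens); a higher number here means faster removal of the compound, a lower number slower removal. Compound 1 `CC1(C)C[C@@H](CN([C@H](CCC(F)(F)F)C(N)=O)S(=O)(=O)c2ccc(Cl)cc2)O1` gives 57.6 mL/min/kg. Compound 2 `NC(=O)[C@@H](CCC(F)(F)F)N(C[C@@H]1CCO1)S(=O)(=O)c1ccc(Cl)cc1` gives 83.9 mL/min/kg. Compound 3 `CC1(C)C[C@H](CN([C@H](CCC(F)(F)F)C(N)=O)S(=O)(=O)c2ccc(Cl)cc2)O1` gives 64.4 mL/min/kg. The number for compound 3 sits close to both others: there is a 1.1-fold higher number from compound 1 to compound 3 (0.05 log units; within the scatter), which fits with the fact that compounds 1 and 3 differ only in the configuration as drawn, and there is a 1.3-fold lower number from compound 2 to compound 3 (0.11 log units; within the scatter). The remaining pair shows a 1.5-fold higher number from compound 1 to compound 2 (0.16 log units; within the scatter). In short, none of the three differs from another beyond the scatter of this assay.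

Compound 4 `NC(=O)[C@@H](CCC(F)(F)F)N(C[C@@H]1CCCO1)S(=O)(=O)c1ccc(Cl)cc1` has not yet been measured. Its difference from compound 3 is oxolan-2-yl in place of 4,4-dimethyloxetan-2-yl on a saturated chain carbon bound to a sulfonamide nitrogen. Within the data shown here, the steps that bear on this change are the two that also replace the ring attached to that chain carbon: the step from compound 1 to compound 2 and the step from compound 2 to compound 3, both within the scatter. On that basis the step of a 1.0-fold higher number from compound 3 to compound 4 (0.00 log units; within the scatter) is expected to stay within the scatter, with no direction to it. Compound 4 is therefore estimated to give 65 mL/min/kg in this assay, with a range from 35 mL/min/kg to 120 mL/min/kg.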

Compound 4, clearance: 323 mL/min/kg
Compound 4: the middle estimate sits 5.0-fold (0.70 log units) below what was measured, and the stated range ends below it.
By their numbers in this assay, from the lowest: compounds 1, 3 and 2 (each within the scatter of the next); then compound 4.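

On the saturated chain carbon bound to a sulfonamide nitrogen, the choice of ring can clearly matter in this assay: replacing 4,4-dimethyloxetan-2-yl with oxolan-2-yl brings a 5.0-fold higher number from compound 3 to compound 4 (0.70 log units; beyond the scatter), and the same change from the other drawn configuration brings a 5.6-fold higher number from compound 1 to compound 4 (0.75 log units; beyond the scatter). Losing the two methyl groups does not by itself go with a step of this size, since compound 2 also lacks them and stays within the scatter of compounds 1 and 3, whereas replacing its oxetan-2-yl with oxolan-2-yl brings a 3.8-fold higher number from compound 2 to compound 4 (0.59 log units; beyond the scatter). Among these four compounds, the three with a four-membered ring sit within the scatter of one another and only compound 4, with its five-membered ring, stands apart, though that separation rests on this single compound.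

Nothing measured here explains this step. On these data alone, it also remains open whether the step belongs to the five-membered ring in general, which an oxolan-2-yl carrying two methyl groups, a six-membered oxane ring, a cyclopentyl group without the ring oxygen or the opposite drawn configuration of oxolan-2-yl could each help to test.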